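This account rests on a few compounds, and the source may have more. Where it says the series, first, only, none or still open, it means among the compounds named here.

Three compounds from this series were tested in a functional assay on BGC-823 cells (Homo sapiens) for cytotoxicity, read by MTT assay, with a stated time of 48 h; on this read-out lower numbers stand for stronger inhibition and higher numbers for weaker inhibition. Compound 1 `CC(C)COc1ccc2c(Cl)ccnc2c1` carries a chlorine on the shared core and an isobutyl group on the aromatic oxygen; in this assay compound 1 gives 3030 nM, the highest of the three numbers and therefore the weakest result in the set. Compound 2 `CCCCCCOc1ccc2c(NCCN(C)C)ccnc2c1` gives 1090 nM in this assay, a clearly lower number than compound 1. Compound 3 `CN(C)CCCNc1ccnc2cc(OCc3ccc(F)cc3)ccc12` gives 490 nM in this assay, lower again and furthest from compound 1. Both of these gaps lie beyond the usual scatter, but they involve several structural changes at once and so say nothing direct about the alkyl group on the oxygen.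

Compound 4 `CC(C)Oc1ccc2c(Cl)ccnc2c1` has not yet been measured. It differs from compound 1 in a single place: isopropyl in place of isobutyl on an oxygen on an aromatic ring. One carbon is removed from the chain on the oxygen and nothing else changes. Among the measured compounds shown here, no measured pair in the set isolates a change of this kind, so the expectation rests on the small size of the alteration alone. The step of a 1.2-fold higher number from compound 1 to compound 4 (0.06 log units; within the scatter) is expected to stay within the usual scatter, with no clear direction. Compound 4 is therefore estimated at 3500 nM in this assay, with a likely range from 1500 nM to 8000 nM.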

Compound 4, half-maximal inhibitory concentration: 2630 nM
Compound 4: the middle estimate sits 1.3-fold (0.12 log units) above what was measured, and the stated range covers the measured number.
By their numbers in this assay, from the lowest: compound 3; then compound 2; then compounds 4 and 1 (each within the scatter of the next).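

In this assay, among the compounds shown here, the exchange of isobutyl for isopropyl on an oxygen on an aromatic ring gives a 1.2-fold lower number from compound 1 to compound 4 (0.06 log units; within the scatter) and is the first comparison in the set that isolates the group on this oxygen, with the chlorine and the rest of the shared core unchanged. At this position, therefore, removing one carbon from the chain leaves the two compounds indistinguishable on this read-out, and the isobutoxy and isopropoxy forms cannot be ranked against each other. No independent evidence on either group accompanies this result.

The compounds shown leave open how this oxygen responds to a larger change while the chlorine stays in place, such as a cyclopropyl group or a chain bearing a carboxylic acid. They also leave open whether the same exchange of isobutyl for isopropyl would read alike when an amine side chain replaces the chlorine, as compound 2 and compound 3 differ from compound 1 in more than one place and cannot answer this.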